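Propyl for methyl on the thiadiazole of compound 1

The compounds below may be only part of what the source reports. "The series", "measured", "known", "first", "only" and "open" are said of these compounds alone.

Working notes on the series. Compound 1 `Cc1nnsc1CO/N=C/c1c(C)nn(C)c1Oc1ccc(F)cc1` is the parent. In a functional assay on SGC-7901 cells (Homo sapiens) for inhibition, read by MTT assay, with a stated time of 48 h (on this read-out lower numbers stand for stronger inhibition and higher numbers for weaker inhibition), compound 1 gives > 50000 nM and this is a limit of the assay rather than a number. Compound 1 therefore stands at the limit of > 50000 nM in this assay, at which 1 of the 3 values shown sits, and its true position on the scale is open. Compound 2 `Cc1cccc(Oc2c(/C=N/OCc3snnc3C)c(C)nn2C)c1` gives 12800 nM in this assay. Compound 3 `Cc1nnsc1CO/N=C/c1c(C)nn(C)c1Oc1ccc(OC(F)(F)F)cc1` gives 11500 nM in this assay. The two measured steps, an at least 3.9-fold lower number from compound 1 to compound 2 (0.59 log units; beyond the scatter) and an at least 4.3-fold lower number from compound 1 to compound 3 (0.63 log units; beyond the scatter), both change the aryl ether of the shared core and leave the (4-methyl-1,2,3-thiadiazol-5-yl)methyl part untouched.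

Compound 4 `CCCc1nnsc1CO/N=C/c1c(C)nn(C)c1Oc1ccc(F)cc1` differs from compound 1 by ethyl in place of hydrogen on a saturated chain carbon bound to an aromatic carbon; cut one bond further out this reads methyl to propyl, 4-methyl-1,2,3-thiadiazol-5-yl to 4-propyl-1,2,3-thiadiazol-5-yl. Going by the values given here, no measured step touches this part, so neither gives a direction for it, and the only fixed point is that compound 1 sits at the limit. Expected, therefore, is an at least 1.1-fold lower number from compound 1 to compound 4 (0.04 log units; that floor lies within the scatter) in this assay rather than a change beyond the scatter, with wide uncertainty. For compound 4 the estimated value in this assay is 45000 nM, within a range of 12000 nM to 150000 nM.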

Compound 4, half-maximal inhibitory concentration: 8640 nM
The estimate for compound 4 lay 5.2-fold (0.72 log units) above the measured number; measured number below the stated range.
By their numbers in this assay, from the lowest: compounds 4, 3 and 2 (each within the scatter of the next). At a limit, above all of these: compound 1.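

In this assay, changing 4-methyl-1,2,3-thiadiazol-5-yl to 4-propyl-1,2,3-thiadiazol-5-yl with the 4-fluorophenyl ether kept gives an at least 5.7-fold lower number from compound 1 to compound 4 (0.76 log units; beyond the scatter). Going by these compounds alone, the earlier steps changed only the aryl ether, so this is the first sign that the thiadiazole substituent, and not the aryl ether alone, bears on the read-out in this assay: ethyl in place of hydrogen on a saturated chain carbon bound to an aromatic carbon is enough to give a step beyond the scatter. Compound 1 stands at a limit of the assay and not at a number, so this step is a floor and its true size stays open: the limit of > 50000 nM in this assay, at which 1 of the 4 values shown sits.

With only methyl and propyl at this place, the compounds shown do not tell whether the effect follows chain length, and a butyl chain, a cyclopropyl group or a chain ending in an amine could settle that. Also open, going by these compounds, is whether propyl on the thiadiazole combines with the 3-methylphenyl ether or the trifluoromethoxy group on the aryl ether to give a lower number than either change alone.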